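Dimethylamino in Place of Phenoxy: Compound 3 to Compound 4

The compounds below may be only part of what the source reports. "The series", "measured", "known", "first", "only" and "open" are said of these compounds alone.

Compound 1, `COc1cc(C)cc(-c2c(-c3ccnc(-c4ccc(C(C)=O)cc4)c3)cnn2CC#N)c1`: -27%
Compound 2, `COc1cc(C)cc(-c2nn(CC#N)cc2-c2ccc(-c3cccc(C(C)=O)c3)nc2)c1`: -58%
Compound 3, `Cc1cc(O)cc(-c2nn(CC#N)cc2-c2ccnc(-c3ccc(Oc4ccccc4)cc3)c2)c1`: -58%

Of the compounds shown here, three have been measured in a functional assay on RXF 393 cells (Homo sapiens) for cytotoxicity, read by sulforhodamine B assay, with a stated time of 48 h, tested at 1 uM; a higher number here means a weaker effect of the compound at the concentration tested, a lower number a stronger effect. Compound 1 gives -27%, compound 2 gives -58% and compound 3 gives -58%. Compound 3 is level with compound 2 at the digits shown, the two of them standing together at the lowest numbers of the three, while compound 1 shows a higher number that lies beyond the scatter of the method.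

The next compound, compound 4, `Cc1cc(O)cc(-c2nn(CC#N)cc2-c2ccnc(-c3ccc(N(C)C)cc3)c2)c1`, has not yet been measured. It differs from compound 3 in one place: dimethylamino in place of phenoxy on an aromatic carbon.

For the measured compounds named here, no pair of measured compounds differs by this kind of exchange, so the size of this step is not known from the data. The remaining parts of compound 3 are kept unchanged in compound 4, and the three measured compounds leave no indication of how this assay answers a change of this kind. Compound 4 is therefore expected to stay close to compound 3, with a step of a number 8 percentage points higher from compound 3 to compound 4 (within the scatter) that is estimated to lie within the scatter. On this basis compound 4 is estimated at -50%, in a range from -78% to -18%, in this assay.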

Compound 4, a percentage reported as activity, at one concentration (the size of the read-out at that concentration, not a potency): -32%
Compound 4: middle estimate off by 18 percentage points, on the low side; the measured number falls inside the stated range.
By their numbers in this assay, from the lowest: compounds 2 and 3 (each within the scatter of the next); then compounds 4 and 1 (each within the scatter of the next).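

In this assay, for the compounds shown here, the exchange of phenoxy for dimethylamino gives a number 26 percentage points higher from compound 3 to compound 4 (beyond the scatter), the first step between compounds that differ in one place, and it shows that the read-out responds to a change on this aromatic carbon, para to a large group. The exchange removes a six-membered aromatic ring of carbon only and reduces the group from 7 heavy atoms to 3, while the count of 0 hydrogen-bond donors and 1 hydrogen-bond acceptor stays the same, so those two counts do not distinguish the groups here. No measured property is available to explain the step.

The compounds shown leave open whether the step follows the loss of the ring, the smaller size of the group or the replacement of the oxygen-linked group by a nitrogen-linked one; methoxy and morpholine at the same place would help to separate these possibilities. Going by these compounds alone, they also leave open whether the same exchange would give a step of similar size with the other substituents around the shared core, since this single pair is the only comparison available.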